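Bis-pyrazole series on KB cells: octyloxy at the central ring

A few compounds are considered here, and "the series" means these few. Any claim that something is new, unique, unknown or untested is made for them only; others in the source may bear on it.

Measured so far:
compound 1 `O=[N+]([O-])c1ccc(-n2cc(-c3ccc(C(F)(F)F)cc3)cn2)cc1`, 21300 nM
compound 2 `Cc1nn(-c2ccc([N+](=O)[O-])cc2)c(C)c1-c1ccccc1-c1c(C)nn(-c2ccc([N+](=O)[O-])cc2)c1C`, 25600 nM
compound 3 `Cc1nn(-c2ccc([N+](=O)[O-])cc2)c(C)c1-c1cccc(-c2c(C)nn(-c3ccc([N+](=O)[O-])cc3)c2C)c1`, 10100 nM

In a functional assay on KB cells (Homo sapiens) for cytotoxicity, read by MTT assay, with a stated time of 48 h (on this read-out higher numbers stand for weaker inhibition and lower numbers for stronger inhibition), compound 3 gives the lowest number of the three; compound 1 and compound 2 both sit beyond the scatter above it, so compound 3 is the strongest inhibitor measured here.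

Compound 4 `CCCCCCCCOc1cc(-c2c(C)nn(-c3ccc([N+](=O)[O-])cc3)c2C)cc(-c2c(C)nn(-c3ccc([N+](=O)[O-])cc3)c2C)c1` is built from compound 3 by one change: octyloxy in place of hydrogen on an aromatic carbon. For the measured compounds named here, no comparable step has been measured, so nothing fixes the direction of this change. The expectation for the step from compound 3 to compound 4 is a 1.3-fold lower number from compound 3 to compound 4 (0.10 log units; within the scatter), a shift that need not exceed the scatter in either direction. On that basis compound 4 is estimated at 8000 nM in this assay, with a range from 3000 nM to 25000 nM.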

Compound 4, half-maximal inhibitory concentration: 6310 nM
For compound 4 the middle estimate is 1.3-fold (0.10 log units) above the measured one; measured number inside the range.
By their numbers in this assay, from the lowest: compounds 4 and 3 (each within the scatter of the next); then compounds 1 and 2 (each within the scatter of the next).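

In this assay the first step measured at this position is a 1.6-fold lower number from compound 3 to compound 4 (0.20 log units; within the scatter), so compound 3 and compound 4 cannot be told apart. Octyloxy in place of hydrogen on an aromatic carbon, meta to two large groups, therefore leaves the number within the scatter despite the size of the added chain. No measurement available here accounts for this result.

From the compounds shown here alone, whether a shorter or longer chain, an amine or a carboxylic acid at this place would give a step beyond the scatter remains open. Going by these compounds, whether octyloxy would behave alike on compound 2 is also open.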